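The source may hold more compounds than are shown below. What is called first, only, known or untested is meant among the compounds shown, and "the series" means these compounds.

In a functional assay on MDA-MB-231 cells (Homo sapiens) for cytotoxicity, read by MTT assay, with a stated time of 48 h (a lower number here means a stronger inhibitor, a higher number a weaker inhibitor), compound 1 `COc1ccc(F)c(C2=NOC(COc3ccc(-c4nnnn4-c4cc(OC)c(OC)c(OC)c4)cc3N)C2)c1` gives 2830 nM and compound 2 `COc1ccc(C2=NOC(COc3ccc(-c4nnnn4-c4cc(OC)c(OC)c(OC)c4)cc3N)C2)cc1[N+](=O)[O-]` gives 3560 nM, so compound 2 stands level with compound 1 within the usual scatter. Compound 3 `COc1cc(-n2nnnc2-c2ccc(OCC3CC(c4ccc(OC)c(OC)c4OC)=NO3)c(N)c2)cc(OC)c1OC` keeps the shared core but carries 2,3,4-trimethoxyphenyl in place of 4-methoxy-3-nitrophenyl on a carbon with a double bond to nitrogen. Among the compounds with values here, the only measured change at this place, a 1.3-fold higher number from compound 1 to compound 2 (0.10 log units; within the scatter), stayed within the scatter, so no shift beyond the scatter is expected in this assay. The expected change is a 1.3-fold lower number from compound 2 to compound 3 (0.12 log units; within the scatter). For compound 3 the estimated value is 2700 nM, with an expected range of 900 nM to 7500 nM.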

Compound 3, half-maximal inhibitory concentration: 3540 nM
Estimate against measurement, compound 3: 1.3-fold (0.12 log units) below; the measured number falls inside the stated range.
By their numbers in this assay, from the lowest: compounds 1, 3 and 2 (each within the scatter of the next).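

At the place on the carbon with a double bond to nitrogen, the step in this assay gives a 1.0-fold lower number from compound 2 to compound 3 (0.00 log units; within the scatter), and the second new step gives a 1.3-fold higher number from compound 1 to compound 3 (0.10 log units; within the scatter), both within the scatter. A third group, 2,3,4-trimethoxyphenyl, with no nitro group or fluorine, therefore reads level with the other two substituted phenyl groups. Nothing at hand explains this flat result.

Still open, going by these compounds, is whether a group without a phenyl ring, such as an amine or a carboxylic acid, would read differently here. Also open, on these data alone, is whether any group at this place can move the number beyond the scatter.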